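Para substituent on the benzoyl ring: fluoro to propyl

The source may hold more compounds than are shown below. What is called first, only, known or untested is meant among the compounds shown, and "the series" means these compounds.

Measured compounds in an assay on cells for agonist activity at ecdysone receptor (Bombyx mori), read by a luciferase reporter, with a stated time of 24 h; a higher number here means that more compound is needed for the effect, a lower number that less compound is needed:
compound 1 `CC(C)(C)N(NC(=O)c1cccc(F)c1)C(=O)c1ccccc1Cl`, 69.2 nM
compound 2 `CC(C)(C)N(NC(=O)c1cccc(C#N)c1)C(=O)c1ccccc1Cl`, 955 nM
compound 3 `CC(C)(C)N(NC(=O)c1ccc(F)cc1)C(=O)c1ccccc1Cl`, 389 nM

Compound 3 stands second highest of the three numbers in this assay; the step of a 2.5-fold lower number from compound 2 to compound 3 (0.39 log units; beyond the scatter) is modest, the step of a 5.6-fold higher number from compound 1 to compound 3 (0.75 log units; beyond the scatter) is modest and runs the other way, so compound 3 sits between the two. Within the data shown here, the largest step so far, a 14-fold higher number from compound 1 to compound 2 (1.14 log units; beyond the scatter), concerns a change on the other position and is not the change at hand.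

Compound 4 `CCCc1ccc(C(=O)NN(C(=O)c2ccccc2Cl)C(C)(C)C)cc1` differs from compound 3 by propyl in place of fluoro on an aromatic carbon. Among the measured compounds shown here, no measured pair shows an alkyl group entering on this ring, and no measured pair touches the position para to a large group other than the fluoro of compound 3 itself. The steps measured for this series only show that the ring substituent matters beyond the scatter, in both directions. The expectation for compound 4 in this assay is therefore a step of a 2.6-fold lower number from compound 3 to compound 4 (0.41 log units; beyond the scatter) that is uncertain in size, with a wide range.

Compound 4 is estimated at 150 nM, expected between 30 nM and 800 nM.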

Compound 4, half-maximal effective concentration: 9.12 nM
For compound 4 the middle estimate is 16-fold (1.22 log units) above the measured one, and the stated range ends above it.
By their numbers in this assay, from the lowest: compound 4; then compound 1; then compound 3; then compound 2.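

In this assay, among these compounds, propyl in place of fluoro on this aromatic carbon gives a 43-fold lower number from compound 3 to compound 4 (1.63 log units; beyond the scatter) and is the largest step so far. Among the compounds shown here, until now, this position had been seen only with fluoro in compound 3, so nothing showed that it could carry a chain of three carbons, let alone that such a chain would go with far less compound being needed. Nothing at hand bears on why the step is this large.

Going by these compounds, it remains open whether the drop follows chain length or the presence of an alkyl group as such: methyl, ethyl, butyl or a branched isopropyl group at this place would separate the two. An amine or a carboxylic acid there would show whether a group other than an alkyl chain can give a comparable step.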